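The compounds below may be only part of what the source reports. "The series", "measured", "known", "first", "only" and "open" are said of these compounds alone.

Measured so far:
compound 1, `COc1ccc(C(=O)/C=C/c2ccc3ccccc3c2)c2c1C=CC(C)(C)O2`, 4480 nM
compound 2, `COc1ccc(C(=O)/C=C/c2ccc(N3CCCC3)cc2)c2c1C=CC(C)(C)O2`, 8360 nM

Both numbers come from a functional assay on HT-29 cells (Homo sapiens) for antiproliferative activity, read by MTT assay, with a stated time of 24 h; a higher number here means a weaker inhibitor, a lower number a stronger inhibitor. Compound 2 gives the highest of the two numbers, and its nearest neighbour is compound 1, whose number is lower but still within the usual scatter of this measurement, so the two cannot be ranked against each other.

Compound 3, `COc1ccc(C(=O)/C=C/c2ccc(Cl)cc2)c2c1C=CC(C)(C)O2`, has not yet been measured in this assay. It differs from compound 2 in one place: chloro in place of pyrrolidin-1-yl on an aromatic carbon. Among the compounds with values here, no step between measured compounds tells how such a swap plays out, so the expectation rests only on the two numbers already in hand, which sit close together.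

Within the data shown here, with no direct precedent, the expected step from compound 2 to compound 3 in this assay is a 1.7-fold lower number from compound 2 to compound 3 (0.22 log units; within the scatter), a small move that may not clear the scatter. Compound 3 is thus estimated at 5000 nM, with a likely range from 1800 nM to 14000 nM.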

Compound 3, half-maximal inhibitory concentration: > 10000 nM
Compound 3: a limit, no number; the forecaster's own chance of this, stated with the estimate: 10%; middle value at least 2.0-fold (0.30 log units) away from the limit.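

In this assay compound 3 gives > 10000 nM as a limit of the assay and not a number: the limit of > 10000 nM in this assay, at which 1 of the 3 values shown sits. Going by these compounds, replacing pyrrolidin-1-yl with chloro on this aromatic carbon therefore yields only a floor for the step (an at least 1.1-fold higher number from compound 2 to compound 3 (0.07 log units; that floor lies within the scatter)), so its true size is unknown and could be much larger. The result adds the first direct view of this position: exchanging a five-membered ring that holds a nitrogen for a single chlorine atom did not lower the number, although the floor alone does not establish a real rise.

The compounds shown leave open how other groups on this carbon, such as dimethylamino, methoxy or a carboxylic acid, would behave. With one swap at this position, they also cannot show whether the nitrogen or the ring of pyrrolidin-1-yl matters more.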